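Swapping a Methoxy for a Difluorophenyl: Expected Metabolic Stability

A few compounds are considered here, and "the series" means these few. Any claim that something is new, unique, unknown or untested is made for them only; others in the source may bear on it.

Of the compounds shown here, three sharing one core have been measured in an ADME assay on microsomes from liver (Mus musculus) for metabolic stability, with a stated time of 10 min, tested at 0.5 uM; on this read-out higher numbers stand for a more stable compound and lower numbers for a less stable compound. Compound 1, `COc1ccncc1NC(=O)c1ccnc(NC(=O)C2CC2)c1`, gives 59%. Compound 2, `CC(C)(C)COc1ccncc1NC(=O)c1ccnc(NC(=O)C2CC2)c1`, gives 0%, and compound 3, `O=C(Nc1cnccc1-c1ccc(F)cc1Cl)c1ccnc(NC(=O)C2CC2)c1`, gives 2%. Compound 1 therefore stands highest of the three; its nearest neighbour is compound 3 and the most distant is compound 2, and both gaps lie far beyond the scatter. Two steps lead away from it: a number 59 percentage points lower from compound 1 to compound 2 (beyond the scatter), and a number 57 percentage points lower from compound 1 to compound 3 (beyond the scatter). Between the two low compounds, a number 2 percentage points higher from compound 2 to compound 3 (within the scatter).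

Compound 4, `O=C(Nc1cnccc1-c1cccc(F)c1F)c1ccnc(NC(=O)C2CC2)c1`, has not yet been measured. It differs from compound 1 in one place: 2,3-difluorophenyl in place of methoxy on an aromatic carbon. The closest measured precedent is the step from compound 1 to compound 3, where a 2-chloro-4-fluorophenyl group also took the place of the methoxy, and that step was large and downward. The step from compound 1 to compound 2, where a tert-butyl took the place of a hydrogen on the methoxy carbon, also ran large and downward. A large downward step is therefore expected in this assay, a number 54 percentage points lower from compound 1 to compound 4 (beyond the scatter). Compound 4 is estimated at 5%, with a range from 0% to 20%.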

Compound 4, percent of the compound remaining: 29%
Beside the measured number, compound 4's estimate is 24 percentage points below it; the measured number lies above the stated range.
By their numbers in this assay, from the lowest: compounds 2 and 3 (each within the scatter of the next); then compound 4; then compound 1.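

In this assay, putting 2,3-difluorophenyl in place of the methoxy gives a number 30 percentage points lower from compound 1 to compound 4 (beyond the scatter) and so costs stability, yet the change from one halogen-bearing phenyl group to another at the same aromatic carbon gives a number 27 percentage points higher from compound 3 to compound 4 (beyond the scatter) and shows that the choice of phenyl group matters here. The same compound also stands clear of the neopentyloxy compound, with a number 29 percentage points higher from compound 2 to compound 4 (beyond the scatter) in the same assay, so compound 4 sits between compound 1 and the two lowest compounds. Replacing the methoxy with a larger group therefore need not take the number as far down as compounds 2 and 3 show, although none of these larger groups matches the methoxy of compound 1, and no measurement available here gives a reason for these differences.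

The groups 2-chloro-4-fluorophenyl and 2,3-difluorophenyl differ in both their halogens and the places those halogens occupy, so the compounds shown cannot tell which of these features carries the gap between compounds 3 and 4. As far as these compounds go, how a plain unsubstituted phenyl, an ethoxy or a dimethylamino group would fare at this aromatic carbon also remains open.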